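This account rests on a few compounds, and the source may have more. Where it says the series, first, only, none or still open, it means among the compounds named here.

Working notes on the series. Among the compounds with values here, compound 2 `CCCCC(CC)C(=O)Nc1ccc2ccn(Cc3ccc(C(=O)NS(=O)(=O)c4ccc(C)cc4)cc3OC)c2c1` gives 8.4 in a functional assay (trachea) for antagonist activity, with Cavia porcellus as the target (a higher number here means a more potent compound, by a factor of ten per unit of this negative logarithm, a lower number a less potent compound), and holds the lowest of the two numbers measured so far; the nearest is compound 1 `CCCCC(CC)C(=O)Nc1ccc2ccn(Cc3ccc(C(=O)NS(=O)(=O)c4ccccc4)cc3OC)c2c1`, at 8.6, a difference within the scatter. Within the data shown here, the only measured step, a number 0.20 log units lower from compound 1 to compound 2 (within the scatter), concerns a methyl on an aromatic carbon. Among the measured compounds shown here, compound 3 `CCCCC(CC)C(=O)Nc1ccc2ccn(Cc3ccc(C(=O)C(C#N)S(=O)(=O)c4ccccc4)cc3OC)c2c1` differs from compound 2 by cyano(phenylsulfonyl)methyl in place of ((4-methylphenyl)sulfonyl)amino on a carbonyl carbon; no measured step touches this part of the molecule, so the direction is open. Compound 3 is estimated at 7.9 in this assay, within 6.8 to 8.9. The expected step of a number 0.50 log units lower from compound 2 to compound 3 (beyond the scatter) carries wide uncertainty.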

Compound 3, negative logarithm of the antagonist equilibrium constant: 8.1
Compound 3: middle estimate off by 0.20 log units, on the low side; low and high end bracket the measured number.
By their numbers in this assay, from the lowest: compounds 3, 2 and 1 (each within the scatter of the next, the first and the last beyond it).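

On the carbonyl carbon, cyano(phenylsulfonyl)methyl gives a result that depends on the comparison in this assay: a number 0.30 log units lower from compound 2 to compound 3 (within the scatter) and a number 0.50 log units lower from compound 1 to compound 3 (beyond the scatter). The entering group has no hydrogen-bond donor, yet compound 3 still gives 8.1 in this series, so the donor of the leaving group is not needed for a number of this order. Nothing at hand bears on the reason for the modest step from the sulfonylamino compound.

On these data alone, whether a carboxylic acid on the same carbonyl carbon would hold the number remains open. So does the effect of an amine there.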